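The compounds below may be only part of what the source reports. "The series", "measured", "known", "first", "only" and "open" are said of these compounds alone.

Measured so far in an assay on isolated protein for inhibition of high affinity 3',5'-cyclic-AMP phosphodiesterase 7A (Homo sapiens), read by cAMP accumulation, with a stated time of 10 min; on this read-out higher numbers stand for weaker inhibition and lower numbers for stronger inhibition:
compound 1 `COc1nc2c(c(=O)n(C)c(=O)n2C)n1CC(=O)Nc1cccc(Cl)c1` — > 200000 nM
compound 2 `CCOc1nc2c(c(=O)n(C)c(=O)n2C)n1CC(=O)Nc1cccc(Cl)c1` — > 200000 nM
compound 3 `CCOc1nc2c(c(=O)n(C)c(=O)n2C)n1CCCC(=O)Nc1ccc(C(C)(C)C)cc1` — 54300 nM

In this assay compound 1 gives > 200000 nM, which is a limit of the assay and not a number. Compound 2 likewise gives > 200000 nM, again a limit. Going by the values given here, compound 3 gives 54300 nM, the only number in the set. The change from compound 1 to compound 2 is methyl in place of hydrogen on a saturated chain carbon bound to an oxygen on an aromatic ring, and it makes a step that the two limits leave unreadable from compound 1 to compound 2: both values sit at the limit of > 200000 nM in this assay, at which 2 of the 3 values shown sit. How the core of compound 1 differs from the core of compound 3 is not broken down here.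

Compound 4 `CCCOc1nc2c(c(=O)n(C)c(=O)n2C)n1CCCC(=O)Nc1ccc(C(C)(C)C)cc1` is not yet measured. It differs from compound 3 by methyl in place of hydrogen on a saturated chain carbon, two bonds along the chain from an oxygen on an aromatic ring, the same kind of change as from compound 1 to compound 2, but the place is not the same: the carbon is two bonds along the chain from an oxygen on an aromatic ring rather than bound to it. Among the compounds with values here, the one earlier instance gives no readable size, so the expected step of a 1.1-fold lower number from compound 3 to compound 4 (0.04 log units; within the scatter) is taken as small and rests on compound 3 at 54300 nM alone. Compound 4 is therefore estimated at 50000 nM, between 15000 nM and 200000 nM.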

Compound 4, half-maximal inhibitory concentration: 7760 nM
Compound 4: middle estimate off by 6.4-fold (0.81 log units), on the high side, and the stated range ends above it.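

On the core of compound 3 in this assay, the change from ethoxy to propoxy gives a 7.0-fold lower number from compound 3 to compound 4 (0.84 log units; beyond the scatter), so an added methyl at this place on the chain can matter on this core. Going by these compounds alone, the only other instance of this kind of change, on the core of compound 1 and at a different place on the chain, cannot be read, as both of its values are limits of the assay and not numbers: the limit of > 200000 nM in this assay, at which 2 of the 4 values shown sit. The series therefore shows one readable step on one core; it does not show that the step carries over to another core, nor how large it would be there.

From the compounds shown here alone, it remains open whether butoxy, a longer chain in the same place, would extend the trend from ethoxy to propoxy or reverse it. Also open, going by these compounds, are the effect of an amine or a carboxylic acid on that chain and whether propoxy would bring the core of compound 1 to a measurable value.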